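Replacing the nitro group of compound 2 with an amino group

The source may report more compounds than this note shows. Statements on the series, on what has been measured and on what is new or still open speak of the compounds shown alone.

Compound 2 `CCCCN1CCC(CNC(=O)c2cc(Cl)c([N+](=O)[O-])c3[nH]cnc23)CC1` carries a nitro group next to its chloro substituent on the shared core and a butyl chain on the piperidine nitrogen. In an assay on membranes from striatum with 5-hydroxytryptamine receptor 4 (Rattus norvegicus) as the target (a lower number here means a stronger inhibitor, a higher number a weaker inhibitor), compound 2 gives 44.7 nM, which places it second highest of the three measured numbers. Its closest neighbour is compound 3 `CCCCN1CCC(CNC(=O)c2cc(Br)c([N+](=O)[O-])c3[nH]cnc23)CC1`, the bromo analogue, which in this assay gives 47.9 nM; the step of a 1.1-fold higher number from compound 2 to compound 3 (0.03 log units; within the scatter) is within the scatter. Far below both stands compound 1 `CC(C)CN1CCC(CNC(=O)c2cc(Cl)cc3[nH]cnc23)CC1`, which has no nitro group and an isobutyl chain, and in this assay gives 0.288 nM; no single-point step connects it to compound 2, so the two values are simply shown side by side.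

Compound 4 `CCCCN1CCC(CNC(=O)c2cc(Cl)c(N)c3[nH]cnc23)CC1` is the unmeasured partner of compound 2. The change is amino in place of nitro on an aromatic carbon. For the measured compounds named here, the only measured step, from compound 2 to compound 3, swaps halogens and does not touch the nitro group, so it gives no direct guide. Because compound 1, which lacks the nitro group, gives 0.288 nM, a lower number is expected for compound 4 than for compound 2, with the step of an 11-fold lower number from compound 2 to compound 4 (1.05 log units; beyond the scatter) expected. Compound 4 is estimated at 4 nM, within a range from 0.8 nM to 20 nM.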

Compound 4, inhibition constant: 22.4 nM
For compound 4 the middle estimate is 5.6-fold (0.75 log units) below the measured one; the measured number lies above the stated range.
By their numbers in this assay, from the lowest: compound 1; then compounds 4, 2 and 3 (each within the scatter of the next, the first and the last beyond it).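

In this assay the swap of nitro for amino gives a 2.0-fold lower number from compound 2 to compound 4 (0.30 log units; within the scatter) and so the two numbers cannot be told apart. For the compounds shown here, this is the first look at a change of the group on this aromatic carbon itself, ortho to a chloro group, since the earlier step altered only the halogen. The two groups differ considerably on paper, with nitro bringing three heavy atoms and a double bond and amino bringing one heavy atom and a hydrogen-bond donor, yet that difference leaves no mark on the number beyond the scatter, and nothing measured here offers an explanation of that.

Compound 1 differs from compound 4 in both the chain on the piperidine nitrogen and the group on this carbon, so its much lower number cannot be assigned to either change alone, and a butyl compound carrying only hydrogen at this carbon would separate the two. On these data alone, it also remains open whether a methoxy or hydroxyl group on this carbon would keep the number within the same scatter.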